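Swapping Imidazole for Piperazine on the Side Chain

A few compounds are considered here, and "the series" means these few. Any claim that something is new, unique, unknown or untested is made for them only; others in the source may bear on it.

- compound 1 `CN(C)CCCCCn1c2c(c3ccccc31)C(=O)c1c[n+]([O-])c3ccccc3c1C2=O`: 470 nM
- compound 2 `O=C1c2c[n+]([O-])c3ccccc3c2C(=O)c2c1c1ccccc1n2CCCCn1ccnc1`: 240 nM

Both numbers come from a functional assay on HCT-116 cells (Homo sapiens) for cytotoxicity, read by MTT assay, with a stated time of 72 h; a lower number here means a stronger inhibitor, a higher number a weaker inhibitor. For the measured compounds named here, the one measured step, a 2.0-fold lower number from compound 1 to compound 2 (0.29 log units; within the scatter), lies within the usual scatter, so these two numbers cannot be told apart. Going by the values given here, compound 2, at 240 nM, therefore stands level with the only other number available, and neither compound can be ranked above the other.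

The next compound is compound 3 `O=C1c2c[n+]([O-])c3ccccc3c2C(=O)c2c1c1ccccc1n2CCCCN1CCNCC1`, which keeps the shared core. Here piperazin-1-yl takes the place of 1H-imidazol-1-yl on a saturated chain carbon, four bonds along the chain from an aromatic nitrogen: piperazin-1-yl in place of 1H-imidazol-1-yl on a saturated chain carbon, four bonds along the chain from an aromatic nitrogen.

Among the compounds with values here, only one measured step bears on this change, the one already described, which altered the group at the same place and stayed within the scatter. Within the data shown here, no measured compound carries piperazin-1-yl, so this evidence is thin and favours no direction. No step beyond the scatter is therefore expected in this assay, and the expected step is small: a 1.3-fold higher number from compound 2 to compound 3 (0.10 log units; within the scatter). For compound 3 the estimate is 300 nM, with an expected range of 100 nM to 850 nM.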

Compound 3, half-maximal inhibitory concentration: 700 nM
Estimate against measurement, compound 3: 2.3-fold (0.37 log units) below; the measured number falls inside the stated range.
By their numbers in this assay, from the lowest: compounds 2, 1 and 3 (each within the scatter of the next, the first and the last beyond it).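

For the compounds shown here, on a saturated chain carbon, four bonds along the chain from an aromatic nitrogen, the choice of ring now makes a readable difference in this assay: piperazin-1-yl in place of 1H-imidazol-1-yl gives a 2.9-fold higher number from compound 2 to compound 3 (0.46 log units; beyond the scatter) in a step that is modest but is the first here to clear the scatter. Piperazin-1-yl in place of (dimethylamino)methyl gives a 1.5-fold higher number from compound 1 to compound 3 (0.17 log units; within the scatter) and so does not separate those two compounds, which leaves compound 1 within the scatter of both compound 2 and compound 3, and only the two ring-bearing compounds apart from each other. Nothing measured here explains the gap between the imidazole and the piperazine.

The compounds shown leave open whether other rings on the same chain, such as a morpholine or a 1,2,4-triazole, would fall nearer compound 2 or compound 3. They also leave open whether the gap would hold on a shorter or a longer chain, or in cell lines other than this one.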